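Cytotoxicity Outlook for a Fused-Ring Analogue, Compound 4

The source may hold more compounds than are shown below. What is called first, only, known or untested is meant among the compounds shown, and "the series" means these compounds.

This series of sulfonylated azetidine amides shares a common core, seen in compound 1 `O=C(NO)c1ccc(N(Cc2ccc(C3CCCC3)cc2)C(=O)[C@H]2CCN2S(=O)(=O)c2c(F)c(F)c(F)c(F)c2F)cc1`, in compound 2 `CONC(=O)c1ccc(N(Cc2ccc(C3CCCCC3)cn2)C(=O)[C@H]2CCN2S(=O)(=O)c2c(F)c(F)c(F)c(F)c2F)cc1O` and in compound 3 `O=C([C@H]1CCN1S(=O)(=O)c1c(F)c(F)c(F)c(F)c1F)N(Cc1ccc(C2CCCCC2)cc1)c1ccc2c(=O)[nH]ccc2c1`, while the aryl part attached to the amide-type nitrogen varies. The read-out of interest is an ADME assay on MCF-10A cells (Homo sapiens) for cytotoxicity, with a stated time of 72 h; on this read-out lower numbers stand for an effect already at smaller amounts and higher numbers for an effect only at larger amounts of compound. In this assay compound 1 gives 7300 nM. In this assay compound 3 gives 5300 nM. For compound 2 the result in this assay is "not determined" (no result reported), so no single number places it among the others; the two numbers that do exist sit close to one another and fall within the usual scatter of repeated measurements, so no order between compound 1 and compound 3 can be read from them.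

The step of interest leads from compound 2 to compound 4 `O=C1NC(=O)c2cc(N(Cc3ccc(C4CCCCC4)cn3)C(=O)[C@H]3CCN3S(=O)(=O)c3c(F)c(F)c(F)c(F)c3F)ccc21`, a compound not yet measured. The change is a group of 11 heavy atoms (8 carbon, 1 nitrogen, 2 oxygen; one five-membered non-aromatic ring with 1 hetero atom, one six-membered aromatic ring of carbon only) in place of a group of 12 heavy atoms (8 carbon, 1 nitrogen, 3 oxygen; one six-membered aromatic ring of carbon only), on an amide-type nitrogen.

Without any pair of measured compounds that differ in a single place, the size and direction of this step cannot be read from the data. The expectation is that compound 4 behaves like its measured relatives, with an effect only at larger amounts. For compound 4 the estimated value in this assay is 6000 nM, with a range from 2500 nM to 15000 nM.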

Compound 4, half-maximal effective concentration: 8100 nM
Estimate against measurement, compound 4: 1.4-fold (0.13 log units) below; measured number inside the range.
By their numbers in this assay, from the lowest: compounds 3, 1 and 4 (each within the scatter of the next).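

In this assay, going by these compounds alone, compound 2 gives no single number, and compound 4 differs from compounds 1 and 3 in more than one place, so no step to compound 4 can be read. No measured evidence bears on this result. The compounds shown leave open how far replacing the 3-hydroxy-4-(methoxycarbamoyl)phenyl group alone shifts cytotoxicity.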